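From Ester to Amide: Estimating Compound 4 Before Measurement

The compounds below may be only part of what the source reports. "The series", "measured", "known", "first", "only" and "open" are said of these compounds alone.

Three measured compounds share one core and differ only in what hangs from the carbonyl carbon. Compound 1 `COCCOC(=O)c1cc(N)c(Nc2ccc(C#N)cc2)cc1Oc1c(C)cc(/C=C/C#N)cc1C` in an ADME assay on microsomes from liver (Homo sapiens) for metabolic stability, read by LC-MS, using NADPH, with a stated time of 45 min, tested at 1 uM (a lower number here means that the compound disappears faster, a higher number that the compound lasts longer), gives 0.317 h. Compound 2 `COC(=O)c1cc(N)c(Nc2ccc(C#N)cc2)cc1Oc1c(C)cc(/C=C/C#N)cc1C` in this assay gives 0.308 h. Compound 3 `Cc1cc(/C=C/C#N)cc(C)c1Oc1cc(Nc2ccc(C#N)cc2)c(N)cc1C(=O)OCCC#N` in this assay gives 0.283 h, the lowest of the three numbers, though its gaps to the other two are within the scatter, so no ordering can be read from them. The three steps between them, a 1.0-fold lower number from compound 1 to compound 2 (0.01 log units; within the scatter), a 1.1-fold lower number from compound 1 to compound 3 (0.05 log units; within the scatter) and a 1.1-fold lower number from compound 2 to compound 3 (0.04 log units; within the scatter), are all within the scatter: exchanging one chain on the oxygen for another left the half-life essentially untouched.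

Compound 4 `Cc1cc(/C=C/C#N)cc(C)c1Oc1cc(Nc2ccc(C#N)cc2)c(N)cc1C(N)=O` goes one step further. amino in place of 2-cyanoethoxy on a carbonyl carbon The 2-cyanoethoxy group leaves entirely and a carbamoyl results, so the oxygen that all three earlier chains were bound to is gone as well. Within the data shown here, none of the measured steps covers a change of this kind; they show only that the chain itself made no difference. For compound 4 a half-life near 0.45 h is therefore estimated, with a range from 0.2 h to 1 h. The expected step of a 1.6-fold higher number from compound 3 to compound 4 (0.20 log units; within the scatter) is modest and may well fall within the scatter.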

Compound 4, half-life: 1.5 h
Compound 4: middle estimate off by 3.3-fold (0.52 log units), on the low side; measured number outside the range, above it.
By their numbers in this assay, from the lowest: compounds 3, 2 and 1 (each within the scatter of the next); then compound 4.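

Among these compounds, exchanging an oxygen-bound chain on the carbonyl carbon for amino, which turns the ester into a primary amide, is the first change at this position that clearly moves the half-life. In this assay the compounds show a 5.3-fold higher number from compound 3 to compound 4 (0.72 log units; beyond the scatter) and a 4.9-fold higher number from compound 2 to compound 4 (0.69 log units; beyond the scatter) and also a 4.7-fold higher number from compound 1 to compound 4 (0.68 log units; beyond the scatter) and all three steps lie beyond the scatter. These steps are close in size whether 2-cyanoethoxy, methoxy or 2-methoxyethoxy leaves, so among these compounds what matters is the exchange of any of these chains for amino, not which chain was there. Nothing shown here explains why the half-life rises, so the step stands as an observation only.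

On these data alone, with a single amide in the set, it remains open whether the higher number depends on the amide hydrogens or simply on the loss of the ester oxygen, and a methylamino or dimethylamino group on the same carbonyl carbon would help to separate these two readings. A carboxylic acid at this position, or a longer chain on the amide nitrogen, would show how far the effect extends beyond this one exchange.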